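Changing the Lactam Nitrogen Substituent in a Spiro-Fused Series

This account rests on a few compounds, and the source may have more. Where it says the series, first, only, none or still open, it means among the compounds named here.

Compound 1, `CN1C(=O)C2(C(C#N)=C(N)Oc3cc4oc(-c5ccccc5)cc(=O)c4c(O)c32)c2ccccc21`: in a functional assay on NCI-H1299 cells (Homo sapiens) for antiproliferative activity, read by MTT assay, with a stated time of 48 h (on this read-out lower numbers stand for stronger inhibition and higher numbers for weaker inhibition), compound 1 gives > 50000 nM, a limit of the assay.
Compound 2, `CN1C(=O)C2(C(C#N)=C(N)Oc3cc4oc(-c5ccccc5)cc(=O)c4c(O)c32)c2cc(Br)ccc21`: in this assay compound 2 gives 7610 nM.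
Compound 3, `N#CC1=C(N)Oc2cc3oc(-c4ccccc4)cc(=O)c3c(O)c2C12C(=O)N(c1ccccc1)c1ccccc12`: in this assay compound 3 gives > 50000 nM, again a limit.

Compound 3 thus stands at the limit, where (the limit of > 50000 nM in this assay, at which 2 of the 3 values shown sit). Compound 4, `CC(C)(C)OC(=O)CN1C(=O)C2(C(C#N)=C(N)Oc3cc4oc(-c5ccccc5)cc(=O)c4c(O)c32)c2ccccc21`, differs from compound 3 by (tert-butoxycarbonyl)methyl in place of phenyl on an amide-type nitrogen in a ring. Going by the values given here, two measured steps bear on this. The change at the same ring nitrogen, a step that the two limits leave unreadable from compound 1 to compound 3, has no readable size. Among the compounds with values here, the only step of readable size, an at least 6.5-fold lower number from compound 1 to compound 2 (0.81 log units; beyond the scatter), concerns the aromatic carbon, a different place. Nothing measured therefore fixes the direction or size of the step to compound 4 in this assay. Compound 4 is expected to stay near the limit, an estimated step of an at least 1.2-fold lower number from compound 3 to compound 4 (0.09 log units; that floor lies within the scatter). The estimate for compound 4 in this assay is 40000 nM, between 12000 nM and 50000 nM.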

Compound 4, half-maximal inhibitory concentration: > 50000 nM
Compound 4: a limit, no number; the forecaster's own chance of this, stated with the estimate: 55%; middle value at least 1.2-fold (0.09 log units) away from the limit.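

In this assay compound 4 also stands at a limit, giving > 50000 nM and so no number. Its steps from compound 1 and from compound 3, themselves limits, cannot be read. The compounds shown leave open whether any group on the amide-type nitrogen in a ring changes the read-out at all.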